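Methoxy added to the benzoyloxy phenyl of compound 1

This account rests on a few compounds, and the source may have more. Where it says the series, first, only, none or still open, it means among the compounds named here.

Measured compounds in an ADME assay on cells (Hepatocyte, Homo sapiens) for metabolic stability, with a stated time of 30 min; on this read-out higher numbers stand for a more stable compound and lower numbers for a less stable compound:
compound 1, `O=C(OC1CCC(CN2CCN(c3cc(=O)c4cc(C(F)(F)F)cc([N+](=O)[O-])c4s3)CC2)CC1)c1ccccc1`, gives 56.4%
compound 2, `O=c1cc(N2CCN(CC3CCC(NS(=O)(=O)c4ccccc4)CC3)CC2)sc2c([N+](=O)[O-])cc(C(F)(F)F)cc12`, gives 90.8%
compound 3, `O=C(OC1CCC(CN2CCN(c3cc(=O)c4cc(C(F)(F)F)cc([N+](=O)[O-])c4s3)CC2)CC1)c1ccncc1`, gives 1%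

Compound 1 stands second highest of the three numbers. Its nearest neighbour is compound 2, reached by the step of a number 34.4 percentage points higher from compound 1 to compound 2 (beyond the scatter), and its furthest is compound 3, reached by a number 55.4 percentage points lower from compound 1 to compound 3 (beyond the scatter). Between compound 2 and compound 3 the step of a number 89.8 percentage points lower from compound 2 to compound 3 (beyond the scatter) is the largest of the set.

Compound 4, `COc1ccc(C(=O)OC2CCC(CN3CCN(c4cc(=O)c5cc(C(F)(F)F)cc([N+](=O)[O-])c5s4)CC3)CC2)cc1`, is not yet measured. It differs from compound 1 in this way: methoxy in place of hydrogen on an aromatic carbon. Among the compounds with values here, of the measured steps only the one to compound 3 touches the same aromatic ring, and it swapped the whole ring rather than adding a substituent; the step to compound 2 replaced the benzoyloxy group altogether. Neither step is a true match for adding a methoxy group, so the direction is uncertain, though both changes at this part of the molecule moved the number far. Compound 4 is therefore expected to land somewhat below compound 1, with a step of a number 11.4 percentage points lower from compound 1 to compound 4 (beyond the scatter), giving an estimate of 45% with a range from 15% to 75%.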

Compound 4, percent of the compound remaining: 12.2%
Beside the measured number, compound 4's estimate is 32.8 percentage points above it, outside the stated range (below it).
By their numbers in this assay, from the lowest: compound 3; then compound 4; then compound 1; then compound 2.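

In this assay, the phenyl of the benzoyloxy group proves sensitive even to a small addition: with methoxy in place of hydrogen, para to a large group, and nothing else changed, the result is a number 44.2 percentage points lower from compound 1 to compound 4 (beyond the scatter). The earlier steps shown here at this part of the molecule exchanged a whole ring or a whole group, whereas this one shows that a single substituent can also move the number far, though the 4-methoxyphenyl still compares with pyridin-4-yl as a number 11.2 percentage points higher from compound 3 to compound 4 (beyond the scatter). The (phenylsulfonyl)amino compound stays well apart from the new compound, with a number 78.6 percentage points lower from compound 2 to compound 4 (beyond the scatter).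

Nothing available here accounts for these steps. As far as these compounds go, it remains open whether a fluorine atom, a methyl or a hydroxyl at the same place would also fall below compound 1, and whether methoxy on the phenyl of compound 2 would bring a similar step.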